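Lengthening the alkyl chain of an acyltransferase inhibitor

A few compounds are considered here, and "the series" means these few. Any claim that something is new, unique, unknown or untested is made for them only; others in the source may bear on it.

Compound 2 `CCCCCCCCCc1ccc(NC(=O)Nc2c(C(C)C)cccc2C(C)C)cc1` holds the lowest number of the two measured compounds in an assay on isolated protein for inhibition of acyl-CoA:cholesterol acyltransferase (Oryctolagus cuniculus); a higher number here means a weaker inhibitor, a lower number a stronger inhibitor: compound 2 gives 9 nM, while compound 1 `CCc1ccc(NC(=O)Nc2c(C(C)C)cccc2C(C)C)cc1` gives 100 nM. The step from compound 1 to compound 2 was an 11-fold lower number from compound 1 to compound 2 (1.05 log units; beyond the scatter), heptyl in place of hydrogen on a saturated chain carbon, two bonds along the chain from an aromatic carbon. Compound 3 `CCCCCCCCCCCc1ccc(NC(=O)Nc2c(C(C)C)cccc2C(C)C)cc1` extends that same chain: ethyl in place of hydrogen on a saturated chain carbon, nine bonds along the chain from an aromatic carbon, the same difference cut one bond further out reading methyl to propyl, ethyl to butyl, propyl to pentyl. Within the data shown here, only that one measured step bears on the change, and it was large; the length added in compound 3 is far smaller than the heptyl added before, so the expected step in this assay is a modest lowering, a 1.5-fold lower number from compound 2 to compound 3 (0.18 log units; within the scatter), possibly not beyond the scatter. Compound 3 is therefore estimated at 6 nM, with a range from 2 nM to 20 nM.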

Compound 3, half-maximal inhibitory concentration: 9 nM
For compound 3 the middle estimate is 1.5-fold (0.18 log units) below the measured one; measured number inside the range.
By their numbers in this assay, from the lowest: compounds 2 and 3 (each within the scatter of the next); then compound 1.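

In this assay the ethyl added nine bonds along the chain from an aromatic carbon gives no change at the digits printed from compound 2 to compound 3 (within the scatter) and so adds nothing measurable to the large gain that came with the heptyl. Read from the short chain, the nonyl in place of hydrogen gives an 11-fold lower number from compound 1 to compound 3 (1.05 log units; beyond the scatter) and matches the printed size of the earlier step, so among these three compounds the whole gain is already present in compound 2. No evidence is available that explains this levelling.

Still open, from the compounds shown here alone, is how a butyl or hexyl chain in place of the ethyl of compound 1 would read, and so where along the chain the gain arises. Also open, going by these compounds, is whether a longer chain than that of compound 3 would hold the number, or whether an amine or a carboxylic acid at the chain end would be tolerated.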